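One aryl swap, two cores: what compound 4 may show

A few compounds are considered here, and "the series" means these few. Any claim that something is new, unique, unknown or untested is made for them only; others in the source may bear on it.

Compound 1 `COc1ccc(N2CCN(C(=S)SCc3nc4cc(C)c(C)cc4[nH]3)CC2)cc1` gives 46000 nM in a functional assay on MCF7 cells (Homo sapiens) for cytotoxicity, read by MTT assay, with a stated time of 24 h; a higher number here means a weaker inhibitor, a lower number a stronger inhibitor.
Compound 2 `CCOc1ccccc1N1CCN(C(=S)SCc2nc3cc(C)c(C)cc3[nH]2)CC1` gives 5580 nM in this assay.
Compound 3 `COc1ccc(N2CCN(CCCSc3nc4ccccc4[nH]3)CC2)cc1` gives 6840 nM in this assay.

The change from compound 1 to compound 2 is 2-ethoxyphenyl in place of 4-methoxyphenyl on an amine nitrogen in a ring; it brought an 8.2-fold lower number from compound 1 to compound 2 (0.92 log units; beyond the scatter). Compound 3 rests on a different core, and the difference between the two cores is not broken down here. Compound 4 `CCOc1ccccc1N1CCN(CCCSc2nc3ccccc3[nH]2)CC1` carries the same change relative to compound 3, namely (2-ethoxyphenyl in place of 4-methoxyphenyl on an amine nitrogen in a ring), at the same place. Among the measured compounds shown here, only one earlier step of this kind is known, on another core, so the transfer is uncertain. A step of a 3.8-fold lower number from compound 3 to compound 4 (0.58 log units; beyond the scatter) is expected, smaller than the earlier one because an 8.2-fold lower number from compound 1 to compound 2 (0.92 log units; beyond the scatter) was measured on a core compound 4 does not share. Compound 4 is therefore estimated at 1800 nM, with a likely range from 500 nM to 7000 nM.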

Compound 4, half-maximal inhibitory concentration: 32700 nM
Beside the measured number, compound 4's estimate is 18-fold (1.26 log units) below it, and the stated range ends below it.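

In this assay the change from 4-methoxyphenyl to 2-ethoxyphenyl gave a 4.8-fold higher number from compound 3 to compound 4 (0.68 log units; beyond the scatter) and so ran the opposite way to the earlier step: the same change on two cores in this assay, an 8.2-fold lower number (0.92 log units; beyond the scatter) from compound 1 to compound 2 and a 4.8-fold higher number (0.68 log units; beyond the scatter) from compound 3 to compound 4, 39-fold (1.60 log units) apart, beyond the scatter of two such steps.
For these two cores, then, the result of this change on one core did not predict its result on the other, in size or in direction. Among the compounds shown here, with only one pair on each core, this does not show which difference between the cores matters, nor how the change would behave on any further core.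

Still open, on these data alone, is how an unsubstituted phenyl group on the same ring nitrogen would compare on each core. Also open, as far as these compounds go, is whether a phenyl group carrying an amine or a carboxylic acid would follow either pair.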